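Chloro to Bromo: Expecting the Next Number

The compounds below may be only part of what the source reports. "The series", "measured", "known", "first", "only" and "open" are said of these compounds alone.

compound 1 `O/N=C(/Nc1cccc(Br)c1)c1ccc2occc2c1`: 440 nM
compound 2 `O/N=C(/Nc1cccc(Cl)c1)c1ccc2oc(COCC3CC3)cc2c1`: 1500 nM

Of the compounds shown here, two have so far been tested in an assay on isolated protein for inhibition of Indoleamine 2,3-dioxygenase 1 (Homo sapiens), read by spectrophotometry; a lower number here means a stronger inhibitor, a higher number a weaker inhibitor. Compound 1 `O/N=C(/Nc1cccc(Br)c1)c1ccc2occc2c1` gives 440 nM in this assay. Compound 2 `O/N=C(/Nc1cccc(Cl)c1)c1ccc2oc(COCC3CC3)cc2c1` gives 1500 nM in this assay, the higher of the two numbers, and its gap to compound 1 lies beyond the scatter. Compound 3 `O/N=C(/Nc1cccc(Br)c1)c1ccc2oc(COCC3CC3)cc2c1` has not yet been measured. It differs from compound 2 by bromo in place of chloro on an aromatic carbon, meta to a large group. For the measured compounds named here, no measured pair differs by this change alone; compound 1 also carries bromo but a different group on the shared core, so its value only shows that a bromo compound can reach a lower number. For compound 3 the expected step is a 1.4-fold lower number from compound 2 to compound 3 (0.13 log units; within the scatter), small and most likely within the scatter, perhaps slightly toward a lower number. Compound 3 is estimated at 1100 nM, with a range from 500 nM to 2500 nM.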

Compound 3, half-maximal inhibitory concentration: 400 nM
Beside the measured number, compound 3's estimate is 2.8-fold (0.44 log units) above it; the measured number lies below the stated range.
By their numbers in this assay, from the lowest: compounds 3 and 1 (each within the scatter of the next); then compound 2.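

In this assay, for the compounds shown here, the change from chloro to bromo on an aromatic carbon, with the rest of the molecule held the same, gives a 3.8-fold lower number from compound 2 to compound 3 (0.57 log units; beyond the scatter), which shows that this single atom matters at this position, something no earlier pair could test. With bromo present on both compounds, (cyclopropylmethoxy)methyl in place of hydrogen on the shared core gives a 1.1-fold lower number from compound 1 to compound 3 (0.04 log units; within the scatter), so the gap between compound 1 and compound 2 does not reflect a cost of that group when bromo is present. Nothing measured here explains why bromo and chloro differ at this position.

The compounds shown leave open whether iodo, methyl or trifluoromethyl on the same carbon would give a lower or higher number than bromo. They also leave open whether chloro to bromo gives a similar step on the core of compound 1, which carries hydrogen in place of the (cyclopropylmethoxy)methyl group.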